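From compound 2 to compound 3: methyl to ethyl

The source may hold more compounds than are shown below. What is called first, only, known or untested is meant among the compounds shown, and "the series" means these compounds.

Values from a functional assay on the whole organism with Mus musculus as the target (on this read-out lower numbers stand for an effect already at smaller amounts and higher numbers for an effect only at larger amounts of compound), follow, each one a limit:
Compound 1 (`c1ccn(Nc2ccncc2)c1`) gives > 20 mg/kg
Compound 2 (`CN(c1ccncc1)n1cccc1`) gives > 20 mg/kg

Compound 2 is known only by its limit (> 20 mg/kg) in this assay and has no exact number. Compound 3 (`CCN(c1ccncc1)n1cccc1`) differs from it by one change (methyl in place of hydrogen on a saturated chain carbon bound to a nitrogen on an aromatic ring), in short methyl to ethyl. Among the compounds with values here, the only measured step bearing on this (a step that the two limits leave unreadable from compound 1 to compound 2) gives no size, and both values sit at one limit (the limit of > 20 mg/kg in this assay, at which 2 of the 2 values shown sit). No shift beyond the scatter is therefore expected in either direction, so the expected step (a step that the limit leaves unreadable from compound 2 to compound 3) stays small. For compound 3 the estimate is 25 mg/kg (expected range 12 mg/kg to 60 mg/kg).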

Compound 3, dose for half-maximal effect: > 20 mg/kg
Compound 3 was reported as a limit; the forecaster's own chance of this, stated with the estimate: 70%; the middle value does not contradict the limit.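

Compound 1, compound 2 and compound 3 are all known only by a limit in this assay, so no step between them can be read: the limit of > 20 mg/kg in this assay, at which 3 of the 3 values shown sit.

The compounds shown leave open what dose any of the three would need for an effect, and whether hydrogen, methyl or ethyl there makes any difference.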